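Swapping Phenyl for Pyridyl on a Benzyl Ether

The compounds below may be only part of what the source reports. "The series", "measured", "known", "first", "only" and "open" are said of these compounds alone.

Measured compounds:
Compound 1 `CN1Cc2ccc(OCc3ccccc3)cc2[C@@H](O)C1` gives > 100000 nM in an ADME assay on Vero cells (Chlorocebus sabaeus) for cytotoxicity, read by sulforhodamine B assay, with a stated time of 72 h (a higher number here means a weaker inhibitor, a lower number a stronger inhibitor), which is a limit of the assay.
Compound 2 `CN1Cc2ccc(OCc3ccc([N+](=O)[O-])cc3)cc2[C@@H](O)C1` gives > 50000 nM, also a limit of the assay.
Compound 3 `CCCCCCCCCCCCOc1ccc2c(c1)[C@@H](O)CN(C)C2` gives 18300 nM.

In this assay compound 1 stands only at a limit, and one further value shown is a limit too. The step that the two limits leave unreadable from compound 1 to compound 2 puts a nitro in place of hydrogen on an aromatic carbon, and its size stays unreadable because both ends sit at limits the limit of > 100000 nM in this assay, at which 1 of the 3 values shown sits (the limit of > 50000 nM in this assay, at which 1 of the 3 values shown sits). Compound 4 `CN1Cc2ccc(OCc3cccnc3)cc2[C@@H](O)C1` differs from compound 1 by pyridin-3-yl in place of phenyl on a saturated chain carbon bound to an oxygen on an aromatic ring. No measured step covers this change, so the shown data give no direction for it. Compound 4 is therefore expected to give 100000 nM (range 30000 nM to 300000 nM), most likely reported again as a limit. The expected step of a number no higher from compound 1 to compound 4 (the limit leaves the size open) means no change beyond the scatter.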

Compound 4, half-maximal inhibitory concentration: > 50000 nM
Compound 4 ended at the assay's limit; the forecaster's own chance of this, stated with the estimate: 80%; the middle value lies beyond the limit too.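

In this assay, the values of compound 1 and compound 4 are both limits of the assay, and no step can be read between them. The compounds shown leave open whether pyridin-3-yl in place of phenyl shifts the result in this assay at all.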